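The source may hold more compounds than are shown below. What is called first, only, known or untested is meant among the compounds shown, and "the series" means these compounds.

Measured so far:
- compound 1, `CNC(=O)c1cncc(NS(=O)(=O)c2cc(Cl)ccc2OC)c1`, 109 nM
- compound 2, `COc1ccc(OC(F)(F)F)cc1S(=O)(=O)Nc1cncc(C(N)=O)c1`, 131 nM
- compound 3, `COc1ccc(C#N)cc1S(=O)(=O)Nc1cccnc1`, 322 nM

All three were tested in an assay on isolated protein for inhibition of alkaline phosphatase, tissue-nonspecific isozyme (Homo sapiens); a higher number here means a weaker inhibitor, a lower number a stronger inhibitor. Compound 1 has the lowest of the three numbers. Compound 2 sits so close to it that the two cannot be told apart within the usual scatter. Compound 3, which carries a nitrile where compounds 1 and 2 carry chlorine or trifluoromethoxy and has no group at all on the ring that holds the sulfonamide nitrogen, gives a clearly higher number, beyond the scatter.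

Compound 4, `COc1ccc(Cl)cc1S(=O)(=O)Nc1cncc(-c2ccc(Cl)cc2)c1`, has not yet been measured in this assay. It shares the core of compound 1 and differs in one place: 4-chlorophenyl in place of methylcarbamoyl on an aromatic carbon. The group that leaves carries a hydrogen-bond donor and acceptor; the group that enters carries none. For the measured compounds named here, no measured pair shows this change, so its effect is not known from the data. Compound 3, which also lacks the methylcarbamoyl, gives 322 nM, but it differs from compound 1 in more than one place, so only the two values themselves can be compared. A modest weakening is expected, with wide uncertainty. Compound 4 is expected to give 260 nM, within 80 nM to 850 nM, an estimated step of a 2.4-fold higher number from compound 1 to compound 4 (0.38 log units; beyond the scatter).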

Compound 4, half-maximal inhibitory concentration: 198 nM
Compound 4: the middle estimate sits 1.3-fold (0.12 log units) above what was measured, within the range that was stated.
By their numbers in this assay, from the lowest: compounds 1, 2, 4 and 3 (each within the scatter of the next, the first and the last beyond it).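

With 4-chlorophenyl in place of methylcarbamoyl on this aromatic carbon, this assay shows a 1.8-fold higher number from compound 1 to compound 4 (0.26 log units; within the scatter) and the two compounds cannot be told apart. In this one pair, a group with no hydrogen-bond donor or acceptor, and with more heavy atoms than the methylcarbamoyl, can stand at this position while the number stays within the scatter of the number for compound 1. Nothing on hand explains this result.

The compounds shown do not tell how a plain phenyl without the chlorine would compare with the 4-chlorophenyl, and so whether that chlorine matters here. Also open, on these data alone, is how very different groups on this same carbon, such as an amine, a carboxylic acid or a longer chain, would read against the shared core.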